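Swapping methyl for methoxy on a pyrazoline amide

The compounds below may be only part of what the source reports. "The series", "measured", "known", "first", "only" and "open" are said of these compounds alone.

Three related compounds have been measured in an assay on isolated protein for inhibition of Amine oxidase [flavin-containing] A (Bos taurus); on this read-out higher numbers stand for weaker inhibition and lower numbers for stronger inhibition. Compound 1 `CCC(=O)N1N=C(c2ccccc2)CC1c1ccc(F)cc1` gives 7240 nM. Compound 2 `CCC(=O)N1N=C(c2ccc(C)cc2)CC1c1ccc(C)cc1` gives 100000 nM, the highest of the three numbers, and compound 3 `CCC(=O)N1N=C(c2ccc(C)cc2)CC1c1ccc(OC)cc1` gives 74100 nM. Compound 2 sits closest to compound 3 and furthest from compound 1.

Compound 4 `CCC(=O)N1N=C(c2ccc(OC)cc2)CC1c1ccc(C)cc1` has not been measured. It differs from compound 2 in one place: methoxy in place of methyl on an aromatic carbon. Among the compounds with values here, the one measured step that bears on this is the exchange of the same two groups made on the other of the two aromatic rings, which gave a 1.3-fold lower number from compound 2 to compound 3 (0.13 log units; within the scatter), a change too small to count. Nothing measured here shows this exchange moving the number beyond the scatter on either ring. For compound 4 in this assay no step beyond the scatter is therefore expected, and the estimated step is a 1.3-fold lower number from compound 2 to compound 4 (0.10 log units; within the scatter). The value of compound 4 is expected to be about 80000 nM, within a range from 30000 nM to 200000 nM.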

Compound 4, half-maximal inhibitory concentration: 7240 nM
The estimate for compound 4 lay 11-fold (1.04 log units) above the measured number; measured number outside the range, below it.
By their numbers in this assay, from the lowest: compounds 1 and 4 (each within the scatter of the next); then compounds 3 and 2 (each within the scatter of the next).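

In this assay, the methyl-to-methoxy exchange on this ring, the change from 4-methylphenyl to 4-methoxyphenyl, gives a 14-fold lower number from compound 2 to compound 4 (1.14 log units; beyond the scatter). The same exchange on the other aromatic ring gave only a 1.3-fold lower number from compound 2 to compound 3 (0.13 log units; within the scatter), so this change cannot be judged from one ring alone: what it does depends on which ring carries it, and the ring altered in compound 4 is the one where it counts. Nothing shown here explains this difference between the two rings.

Going by these compounds, it remains open whether the gain is particular to methoxy or would also appear with a hydroxyl group, an ethoxy group or an amine at this place. Also open, on these data alone, is what methoxy on both aromatic rings together would give.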